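Adding a chain double bond to compound 1

A few compounds are considered here, and "the series" means these few. Any claim that something is new, unique, unknown or untested is made for them only; others in the source may bear on it.

In a functional assay on HeLa cells (Homo sapiens) for antiproliferative activity, read by MTT assay, with a stated time of 48 h (on this read-out higher numbers stand for weaker inhibition and lower numbers for stronger inhibition), compound 1 (`COc1cc(CNC(=O)CCCCCCC(C)C)ccc1OC(=O)CCC(=O)Oc1ccc(-c2cc(=S)ss2)cc1`) gives 5530 nM as the lowest of the two numbers shown. Compound 2 (`COc1cc(CNC(=O)CCCC/C=C/C(C)C)ccc1OC(=O)c1ccc(C(N)=S)cc1`) gives 39600 nM as a higher number, a gap beyond the scatter. Compound 3 (`COc1cc(CNC(=O)CCCC/C=C/C(C)C)ccc1OCCCCOc1ccc(C(N)=S)cc1`) gives > 50000 nM as a limit of the assay and not a number. Compound 4 (`COc1cc(CNC(=O)CCCC/C=C/C(C)C)ccc1OC(=O)CCC(=O)Oc1ccc(-c2cc(=S)ss2)cc1`) differs from compound 1 in one place (3-methylbut-1-en-1-yl in place of isopentyl on a saturated chain carbon, four bonds along the chain from a carbonyl carbon): 3-methylbut-1-en-1-yl stands in place of isopentyl on a saturated chain carbon, four bonds along the chain from a carbonyl carbon. Among the measured compounds shown here, no measured pair isolates this change, and no step beyond the scatter is expected in this assay for it. The expected step of a 1.1-fold lower number from compound 1 to compound 4 (0.04 log units; within the scatter) stays within the scatter. Compound 4 is estimated to give 5000 nM with 2400 nM to 11000 nM as its range.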

Compound 4, half-maximal inhibitory concentration: 4250 nM
For compound 4 the middle estimate is 1.2-fold (0.07 log units) above the measured one; measured number inside the range.
By their numbers in this assay, from the lowest: compounds 4 and 1 (each within the scatter of the next); then compound 2. At a limit, above all of these: compound 3.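

In this assay, among the compounds shown here, the pair gives a 1.3-fold lower number from compound 1 to compound 4 (0.11 log units; within the scatter), the first measured step to isolate 3-methylbut-1-en-1-yl in place of isopentyl on a saturated chain carbon, four bonds along the chain from a carbonyl carbon. On the core of compound 1, this added double bond therefore leaves the read-out within the scatter. Nothing measured here gives a reason for this result.

The compounds shown leave open whether a longer chain or a carboxylic acid in place of isopentyl at this place would give a step beyond the scatter.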